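Removing the ortho chloro from a ketone bearing a pyrrolidine side chain

The compounds below may be only part of what the source reports. "The series", "measured", "known", "first", "only" and "open" are said of these compounds alone.

Compound 1, `Cc1nnc(CN(C)C)n1-c1ccc(Cl)cc1C(=O)c1ccccc1`: 0.5 mg/kg
Compound 2, `Cc1nnc(CN2CCCC2)n1-c1ccc(Cl)cc1C(O)c1ccccc1`: 8 mg/kg; 32 mg/kg (2 entries)
Compound 3, `Cc1nnc(CN2CCCC2)n1-c1ccc(Cl)cc1C(=O)c1ccccc1Cl`: 1.8 mg/kg

Of the compounds shown here, three sharing the same core have been measured in a functional assay on the whole organism (strain CF-1) for inhibition, with Mus musculus as the target; on this read-out lower numbers stand for an effect already at smaller amounts and higher numbers for an effect only at larger amounts of compound. Compound 1 gives 0.5 mg/kg, the lower of the two single numbers. Compound 2 has no single number; instead (the several entries of compound 2 in this assay, 8 mg/kg; 32 mg/kg (2 entries)), and these entries spread wider than the usual scatter. Compound 3 gives 1.8 mg/kg and therefore stands at the higher of the two single numbers, with compound 1 below it by more than the scatter.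

Compound 4, `Cc1nnc(CN2CCCC2)n1-c1ccc(Cl)cc1C(=O)c1ccccc1`, has not yet been measured. It differs from compound 3 by hydrogen in place of chloro on an aromatic carbon. Among the compounds with values here, no step of exactly this kind has been measured, so the expected effect is taken from the spread of the numbers at hand. The step of a 1.4-fold higher number from compound 3 to compound 4 (0.14 log units; within the scatter) is expected to remain within the scatter, with a slight lean toward a higher number. Compound 4 is thus estimated at 2.5 mg/kg, with a range from 0.7 mg/kg to 8 mg/kg.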

Compound 4, dose for half-maximal effect: 0.4 mg/kg
Beside the measured number, compound 4's estimate is 6.3-fold (0.80 log units) above it, and the stated range ends above it.
By their numbers in this assay, from the lowest: compounds 4 and 1 (each within the scatter of the next); then compound 3.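

In this assay, within the data shown here, the exchange of chloro for hydrogen on this aromatic carbon gives a 4.5-fold lower number from compound 3 to compound 4 (0.65 log units; beyond the scatter), so turning the 2-chlorophenyl into a phenyl is a change this read-out registers, which no earlier pair could show. With the phenyl in place, the side chain gives a 1.3-fold lower number from compound 1 to compound 4 (0.10 log units; within the scatter), so pyrrolidin-1-yl and dimethylamino on the chain carbon cannot be told apart here, and the number of compound 3 traces to the chloro rather than to the pyrrolidine. Nothing at hand bears on why the chloro has this effect.

Open, from the compounds shown here alone, is whether fluoro, methyl or methoxy at this place would fall with compound 3 or with compound 4. Also open, going by these compounds, is whether the same chloro step would hold with dimethylamino on the side chain.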